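The source may hold more compounds than are shown below. What is called first, only, known or untested is meant among the compounds shown, and "the series" means these compounds.

In a functional assay on RKO cells (Homo sapiens) for cytotoxicity, read by resazurin assay, with a stated time of 72 h (on this read-out higher numbers stand for weaker inhibition and lower numbers for stronger inhibition), compound 1 `Cc1ccc(Nc2nc(-n3ccnc3C)cs2)cc1` gives > 100000 nM, which is a limit of the assay and not a measured number. A second compound, compound 2 `COc1ccc(Nc2nc(-n3cnc4ccccc43)cs2)cc1`, belongs to the same set. In this assay compound 2 gives > 100000 nM, again a limit rather than a number. Compound 1 thus stands where every measured compound stands, at the limit of > 100000 nM in this assay, at which 2 of the 2 values shown sit. Among the compounds with values here, no step between compound 1 and compound 2 is computed; their two values show only that neither reaches a measurable concentration in this assay.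

Compound 3 `Cc1nccn1-c1csc(Nc2ccc(Br)cc2)n1` is the compound not yet measured. It differs from compound 1 by bromo in place of methyl on an aromatic carbon: a bromo enters where a methyl leaves, on an aromatic carbon of a six-membered aromatic ring of carbon only. Within the data shown here, no measured step anchors this change, so the expectation in this assay is no step beyond the scatter, and the step expected is a number no higher from compound 1 to compound 3 (the limit leaves the size open). Compound 3 is expected to give 100000 nM, within a range from 30000 nM to 300000 nM, most probably reported once more as a limit.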

Compound 3, half-maximal inhibitory concentration: > 100000 nM
Compound 3 ended at the assay's limit; the forecaster's own chance of this, stated with the estimate: 75%; the middle value sits exactly at the limit.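

No step can be read from compound 1 to compound 3 in this assay, as the values of both are limits of the assay and not numbers: the limit of > 100000 nM in this assay, at which 3 of the 3 values shown sit.

The compounds shown leave open whether bromo in place of methyl on an aromatic carbon changes the read-out at all, and which structural change would bring a value within the measurable range of this assay.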